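The source may hold more compounds than are shown below. What is called first, only, known or untested is meant among the compounds shown, and "the series" means these compounds.

Compound 1 `Fc1ccccc1Cc1nc(-c2nc(C(F)(F)F)n[nH]2)n2ccccc12` gives 6 10^-6 cm/s in an ADME assay on MDCKII-LE cells (Canis lupus familiaris) for permeability, in the apical to basolateral direction (on this read-out lower numbers stand for lower permeability and higher numbers for higher permeability), the lowest of the three numbers in hand; compound 3 `Fc1ncncc1Cn1nc(-c2nc(C(F)(F)F)n[nH]2)c2cccnc21` gives 20 10^-6 cm/s in this assay and compound 2 `Cc1ncc(Cc2nc(-c3nc(C(F)(F)F)n[nH]3)n3ccccc23)cn1` gives 27 10^-6 cm/s in this assay. Going by the values given here, the one single-point step measured, a 4.5-fold higher number from compound 1 to compound 2 (0.65 log units; beyond the scatter), concerns the group on the saturated chain carbon and not the five-membered aromatic ring with 3 nitrogen. Compound 4 `NC(=O)c1n[nH]c(-c2nc(Cc3ccccc3F)c3ccccn23)n1` differs from compound 1 by carbamoyl in place of trifluoromethyl on an aromatic carbon. Among the compounds with values here, no measured step bears on this change, so the expectation rests on compound 1 alone and is held loosely. For compound 4 in this assay a value of 2 10^-6 cm/s is expected, within a range of 0.5 10^-6 cm/s to 6 10^-6 cm/s. This estimate corresponds to an expected step of a 3.0-fold lower number from compound 1 to compound 4 (0.48 log units; beyond the scatter), downward and beyond the scatter.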

Compound 4, apparent permeability in the MDCKII-LE assay: 13 10^-6 cm/s
Compound 4: middle estimate off by 6.5-fold (0.81 log units), on the low side, outside the stated range (above it).
By their numbers in the MDCKII-LE assay, from the lowest: compound 1; then compounds 4, 3 and 2 (each within the scatter of the next, the first and the last beyond it).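

Going by these compounds alone, in the MDCKII-LE assay, carbamoyl in place of trifluoromethyl on this aromatic carbon gives a 2.2-fold higher number from compound 1 to compound 4 (0.34 log units; beyond the scatter), the first reading at this position, which the earlier step left untouched. In a physicochemical assay for lipophilicity, measured as octanol-water partition, at pH 7.4 (on this read-out higher numbers stand for higher lipophilicity and lower numbers for lower lipophilicity), compound 1 gives 3.8 and compound 4 gives 2.8, so on this one pair the two read-outs move in opposite directions. A carbamoyl group carrying a hydrogen-bond donor therefore costs nothing on the MDCKII-LE assay read-out here. Going by these compounds, what a carboxylic acid or an amine on this aromatic carbon would give remains open, as does whether carbamoyl gives a similar step on the core of compound 2.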